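The source may report more compounds than this note shows. Statements on the series, on what has been measured and on what is new or still open speak of the compounds shown alone.

Measured so far:
compound 1 `C[C@H](Nc1nc(N)nc(N)c1C#N)c1cc2ccc(F)cn2c(=O)c1-c1ccccc1`: 88%
compound 2 `Cc1nc(N)nc(N[C@@H](C)c2cc3ccc(F)cn3c(=O)c2-c2ccccc2)c1C#N`: 41%

In an ADME assay on microsomes from liver (Rattus norvegicus), read by LC-MS, using NADPH, with a stated time of 30 min, tested at 1 uM (on this read-out higher numbers stand for a more stable compound and lower numbers for a less stable compound), compound 1 gives 88%, the higher of the two numbers. Compound 2 gives 41%, and the step of a number 47 percentage points lower from compound 1 to compound 2 (beyond the scatter) came with methyl in place of amino on an aromatic carbon. Compound 3 `Cc1c([C@H](C)Nc2nc(N)nc(N)c2C#N)c(-c2ccccc2)c(=O)n2cc(F)ccc12` is compound 1 with methyl in place of hydrogen on an aromatic carbon, on an aromatic carbon of the shared core, ortho to a fused ring. Among the compounds with values here, no measured step shows this same change, and the step from compound 1 to compound 2 concerns a different place, so it is only a loose guide. A modest drop, or none beyond the scatter, is expected. Compound 3 is estimated at 75%, between 45% and 92%. The step of a number 13 percentage points lower from compound 1 to compound 3 (beyond the scatter) is therefore expected.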

Compound 3, percent of the compound remaining: 85%
Estimate against measurement, compound 3: 10 percentage points below; low and high end bracket the measured number.
By their numbers in this assay, from the lowest: compound 2; then compounds 3 and 1 (each within the scatter of the next).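

In this assay, methyl in place of hydrogen on this aromatic carbon, ortho to a fused ring, gave a number 3 percentage points lower from compound 1 to compound 3 (within the scatter), so the two compounds cannot be told apart. This position of the shared core therefore accepts a methyl with no measurable loss of stability, whereas methyl in place of amino elsewhere gave a number 47 percentage points lower from compound 1 to compound 2 (beyond the scatter). No available evidence explains this difference between the two places.

Still open, going by these compounds, is whether this position would accept something larger, such as a longer carbon chain, or a group of a different kind, such as an amine or a carboxylic acid.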